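Hydroxypropyl removal on the fused-ring nitrogen

The source may report more compounds than this note shows. Statements on the series, on what has been measured and on what is new or still open speak of the compounds shown alone.

Compound 1 `Cn1c(Cc2nn(C)c(=O)c3ccccc23)nnc1SCCCCCCCC(=O)Nc1ccc(Cl)cc1Cl`: 190 nM
Compound 2 `Cn1c(Cc2nn(CCCO)c(=O)c3ccccc23)nnc1SCCCCCCCC(=O)Nc1ccc(Cl)cc1Cl`: a limit only

In an assay on NK92 cells for inhibition of interleukin-15 (Homo sapiens), read by AlphaScreen, with stated times of 30 min and 1 h (a lower number here means a stronger inhibitor, a higher number a weaker inhibitor), compound 1 gives 190 nM. Compound 2 is reported only as a limit, > 30000 nM, which is the limit of > 30000 nM in this assay, at which 1 of the 2 values shown sits. For the measured compounds named here, the one measured step, an at least 150-fold higher number from compound 1 to compound 2 (2.19 log units; beyond the scatter), is large. Compound 3 `Cn1c(Cc2n[nH]c(=O)c3ccccc23)nnc1SCCCCCCCC(=O)Nc1ccc(Cl)cc1Cl` carries hydrogen in place of 3-hydroxypropyl on an aromatic nitrogen, removing a chain of the kind whose addition gave that large step, so a large fall in number is expected, placing compound 3 close to compound 1. For compound 3 the expected step is an at least 60-fold lower number from compound 2 to compound 3 (1.77 log units; beyond the scatter). Compound 3 is estimated at 500 nM, in the range 100 nM to 5000 nM.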

Compound 3, half-maximal inhibitory concentration: 20000 nM
For compound 3 the middle estimate is 40-fold (1.60 log units) below the measured one; the measured number lies above the stated range.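

In this assay the small methyl on this aromatic nitrogen is needed in its own right: hydrogen in its place costs nearly as much as the long chain does (a 110-fold higher number from compound 1 to compound 3 (2.02 log units; beyond the scatter)). Of the three groups at this position, only methyl keeps the number low. Compound 2 stands only as a limit: the limit of > 30000 nM in this assay, at which 1 of the 3 values shown sits. Its step therefore gives no order between hydrogen and 3-hydroxypropyl (an at least 1.5-fold lower number from compound 2 to compound 3 (0.17 log units; that floor lies within the scatter)).

From the compounds shown here alone, it remains open whether ethyl or a plain propyl chain would hold the number of compound 1, and whether a terminal amine or carboxylic acid on the chain would change the result.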